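The compounds below may be only part of what the source reports. "The series", "measured", "known", "first", "only" and "open" are said of these compounds alone.

Compound 1, `COc1cc(C(c2ccc(O)c(OC)c2)[C@@H](C)[C@@H](C)CO)ccc1O`, in a functional assay on HeLa cells (Homo sapiens) for cytotoxicity, read by WST assay, with a stated time of 48 h (on this read-out higher numbers stand for weaker inhibition and lower numbers for stronger inhibition), sits at the assay limit, > 100000 nM.
Compound 2, `COc1cc(C(c2ccc(O)c(OC)c2)[C@H](CF)C(C)C)ccc1O`, in this assay gives 19000 nM.
Compound 3, `COc1cc(C(c2ccc(O)c(OC)c2)[C@@H](C)[C@H](C)CO)ccc1O`, in this assay sits at the assay limit, > 100000 nM.

Compound 3 stands at the limit, as compound 1 does; only compound 2 returns a number, and an at least 5.2-fold higher number from compound 2 to compound 3 (0.72 log units; beyond the scatter) places compound 3 as the weaker of those two. Compound 1 and compound 3 differ only in configuration, and a step that the two limits leave unreadable from compound 1 to compound 3 is unreadable because the limit of > 100000 nM in this assay, at which 2 of the 3 values shown sit, caps both values. Compound 4, `COC[C@@H](C)[C@H](C)C(c1ccc(O)c(OC)c1)c1ccc(O)c(OC)c1`, carries methyl in place of hydrogen on an oxygen on a saturated carbon. Neither an at least 5.2-fold lower number from compound 1 to compound 2 (0.72 log units; beyond the scatter) nor an at least 5.2-fold higher number from compound 2 to compound 3 (0.72 log units; beyond the scatter) concerns this exchange; both swap the whole hydroxymethyl-bearing chain for a fluoromethyl one. Within the data shown here, no measured step addresses hydroxy to methoxy, so no step beyond the scatter is expected in this assay, and compound 4 is expected to show a number no higher from compound 3 to compound 4 (the limit leaves the size open). Compound 4 is estimated at 100000 nM, between 30000 nM and 300000 nM.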

Compound 4, half-maximal inhibitory concentration: 58000 nM
Compound 4: the middle estimate sits 1.7-fold (0.24 log units) above what was measured; the range from low to high includes it.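

In this assay, methyl on the oxygen gives this hydroxymethyl chain its first readable number, yet an at least 1.7-fold lower number from compound 3 to compound 4 (0.23 log units; that floor lies within the scatter) and an at least 1.7-fold lower number from compound 1 to compound 4 (0.23 log units; that floor lies within the scatter) are floors only, and the true size of the change stays unknown because of the assay limit: the limit of > 100000 nM in this assay, at which 2 of the 4 values shown sit.
The fluoromethyl chain keeps the lower number, with a 3.1-fold higher number from compound 2 to compound 4 (0.48 log units; beyond the scatter).

As far as these compounds go, whether the drawn configuration matters for the methoxymethyl chain stays open. Also open, from the compounds shown here alone, is how an aminomethyl group, a carboxylic acid or a longer ether such as ethoxymethyl would read at this chain end.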